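Swapping 1-benzofuran-2-yl for iodo on the shared core

The source may report more compounds than this note shows. Statements on the series, on what has been measured and on what is new or still open speak of the compounds shown alone.

Three compounds share one core and differ in a single ring group: compound 1 `Cc1nc(N)c2c(-c3cccs3)cn([C@@H]3O[C@H](CO)[C@@H](O)[C@H]3O)c2n1`, compound 2 `Cc1nc(N)c2c(-c3ccccc3)cn([C@@H]3O[C@H](CO)[C@@H](O)[C@H]3O)c2n1` and compound 3 `Cc1nc(N)c2c(-c3cc4ccccc4o3)cn([C@@H]3O[C@H](CO)[C@@H](O)[C@H]3O)c2n1`. In a functional assay on HepG2 cells (Homo sapiens) for antiproliferative activity, read by XTT assay, with a stated time of 72 h (on this read-out higher numbers stand for weaker inhibition and lower numbers for stronger inhibition), compound 1 gives > 20000 nM, which is a limit and not a number. Compound 2 gives > 20000 nM, again a limit. Compound 3 gives > 20000 nM, also a limit, so it stands level with the other two (the limit of > 20000 nM in this assay, at which 3 of the 3 values shown sit).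

Compound 4 `Cc1nc(N)c2c(I)cn([C@@H]3O[C@H](CO)[C@@H](O)[C@H]3O)c2n1` carries iodo in place of 1-benzofuran-2-yl on an aromatic carbon of the five-membered aromatic ring with 1 nitrogen (iodo in place of 1-benzofuran-2-yl on an aromatic carbon). For the measured compounds named here, three measured steps bear on this change: a step that the two limits leave unreadable from compound 1 to compound 2, a step that the two limits leave unreadable from compound 1 to compound 3 and a step that the two limits leave unreadable from compound 2 to compound 3. None has a readable size. Going by the values given here, they show only that exchanging one ring group for another left all three compounds at the limit. Iodo brings no ring, so these steps may not carry over to this change. With compound 3 at > 20000 nM, a limit, only a move toward stronger inhibition could appear as a number. A modest gain or no readable change is therefore expected, and the expected step is an at least 2.0-fold lower number from compound 3 to compound 4 (0.30 log units; that floor lies within the scatter). For compound 4 the estimated value in this assay is 10000 nM, with an expected range from 1000 nM to 20000 nM.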

Compound 4, half-maximal inhibitory concentration: 6310 nM
Compound 4: middle estimate off by 1.6-fold (0.20 log units), on the high side, and the stated range covers the measured number.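

In this assay, iodo is the only group among those shown that gives this position a readable number, with an at least 3.1-fold lower number from compound 3 to compound 4 (0.50 log units; beyond the scatter). The comparison with the two other ring groups gives the same picture, with an at least 3.1-fold lower number from compound 2 to compound 4 (0.50 log units; beyond the scatter) and an at least 3.1-fold lower number from compound 1 to compound 4 (0.50 log units; beyond the scatter), so the shared core can reach a measurable antiproliferative effect when a single iodine atom stands on this aromatic carbon in place of a ring group. The steps among compounds 1, 2 and 3 cannot be read, and what those three compounds share is a limit and not a number: the limit of > 20000 nM in this assay, at which 3 of the 4 values shown sit.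

From the compounds shown here alone, whether the gain belongs to iodine itself or simply follows from having no ring at this position remains open, and a chloro group, a methyl group or an amine on the same carbon would help to separate those two readings. Going by these compounds, how much weaker compounds 1, 2 and 3 really are also remains unknown, so the full size of each step to compound 4, and any order among the three ring groups, stays undetermined.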